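The compounds below may be only part of what the source reports. "The series", "measured", "known", "first", "only" and "open" are said of these compounds alone.

Measured so far in a functional assay on M14 cells (Homo sapiens) for inhibition, read by sulforhodamine B assay, with a stated time of 48 h; a higher number here means that more compound is tolerated, a lower number that less compound is tolerated:

- compound 1, `Nc1cc(N)c2nc(-c3ccccc3)c(Oc3ccc(Cl)c(Cl)c3)nc2c1`: in this assay compound 1 gives < 100000 nM, a limit of the assay and not a number.
- compound 2, `Nc1cc(N)c2nc(-c3ccccc3)c(NCc3ccc(F)cc3)nc2c1`: in this assay compound 2 gives < 100000 nM, again a limit.
- compound 3, `Nc1cc(N)c2nc(-c3ccccc3)c(Sc3ccc(Cl)c(Cl)c3)nc2c1`: in this assay compound 3 gives < 100000 nM, also a limit.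

Compound 3 therefore stands nowhere definite on the numbers shown: all three values sit at the same limit, as summarised by the limit of < 100000 nM in this assay, at which 3 of the 3 values shown sit, and none of the three compounds can be placed relative to another. The steps among them, a step that the two limits leave unreadable from compound 1 to compound 2, a step that the two limits leave unreadable from compound 1 to compound 3 and a step that the two limits leave unreadable from compound 2 to compound 3, are all unreadable, since both ends of each are limits.

The next compound, compound 4, `Nc1cc(N)c2nc(-c3ccccc3)c(Sc3ccc(F)cc3)nc2c1`, differs from compound 3 by 4-fluorophenyl in place of 3,4-dichlorophenyl on a sulfur. For the measured compounds named here, none of the measured steps touches this exchange on the sulfur; the nearest comparison, the change from compound 1 to compound 2, swaps a whole substituent and is itself unreadable. No size or direction of step in this assay can be read from the data, so no step beyond the scatter is assumed.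

Compound 4 is accordingly expected near 50000 nM, with a range from 5000 nM to 100000 nM, and most likely to be reported again only as a limit. The step from compound 3 to compound 4 is estimated as a step that the limit leaves unreadable from compound 3 to compound 4.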

Compound 4, concentration lethal to 50% of the cells: 58900 nM
Beside the measured number, compound 4's estimate is 1.2-fold (0.07 log units) below it; the range from low to high includes it.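

No step from compound 1, compound 2 or compound 3 to compound 4 can be read in this assay, because compound 1, compound 2 and compound 3 each stand only at a limit of the assay: the limit of < 100000 nM in this assay, at which 3 of the 4 values shown sit.

The compounds shown leave open whether 4-fluorophenyl and 3,4-dichlorophenyl on the sulfur differ at all in this read-out.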